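The source may hold more compounds than are shown below. What is called first, only, known or untested is meant among the compounds shown, and "the series" means these compounds.

Compound 1, `C=C1C[C@]23C[C@@]1(O)CC[C@H]2c1cc(Br)c(O)c(C)c1[C@@H]3Cn1cc(-c2ccc(C)cc2)nn1`: in a functional assay on SW480 cells (Homo sapiens) for cytotoxicity, read by MTT assay, with a stated time of 4 days (a higher number here means a weaker inhibitor, a lower number a stronger inhibitor), compound 1 gives a value that is only a limit of the assay, > 20000 nM.
Compound 2, `C=C1C[C@]23C[C@@]1(O)CC[C@H]2c1ccc(O)c(C)c1[C@@H]3Cn1cc(-c2ccc(C)cc2)nn1`: in this assay compound 2 likewise gives only a limit of the assay, > 20000 nM.
Compound 3, `C=C1C(=O)[C@]23C[C@@]1(O)CC[C@H]2c1ccc(O)c(C)c1[C@@H]3Cn1cc(-c2ccccn2)nn1`: in this assay compound 3 gives 410 nM.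

Compound 1 therefore stands at the limit of the assay, and compound 3 is the only one of the three with a numbered value. The step from compound 1 to compound 2, a step that the two limits leave unreadable from compound 1 to compound 2, cannot be sized because both ends sit at the limit of > 20000 nM in this assay, at which 2 of the 3 values shown sit.

Compound 4, `C=C1C[C@]23C[C@@]1(O)CC[C@H]2c1cc(Br)c(O)c(C)c1[C@@H]3Cn1cc(-c2ccc(C(F)(F)F)cc2)nn1`, has not yet been measured. It differs from compound 1 by trifluoromethyl in place of methyl on an aromatic carbon. Going by the values given here, no measured step touches this position, so there is nothing to size the change by; the only evidence on compound 1 is the limit of > 20000 nM in this assay, at which 2 of the 3 values shown sit. With compound 1 at the limit of the assay, compound 4 is expected to remain there or near it, a step that the limit leaves unreadable from compound 1 to compound 4 that cannot be separated from the scatter. The estimate for compound 4 in this assay is 25000 nM, within 5000 nM to 100000 nM.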

Compound 4, half-maximal inhibitory concentration: 15200 nM
Compound 4: the middle estimate sits 1.6-fold (0.22 log units) above what was measured; the measured number falls inside the stated range.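

Going by these compounds alone, this is the first readable step at this position: in this assay, trifluoromethyl in place of methyl on the aromatic carbon para to a large group gives an at least 1.3-fold lower number from compound 1 to compound 4 (0.11 log units; that floor lies within the scatter). The change from 4-methylphenyl to 4-(trifluoromethyl)phenyl therefore yields a numbered value on the brominated core, but the smallest step it allows cannot be told apart from repeat-to-repeat scatter. Its true size stays unknown because the value for compound 1 is only a limit of the assay: the limit of > 20000 nM in this assay, at which 2 of the 4 values shown sit.

The compounds shown leave open how an amine, a carboxylic acid or a longer chain would read at this same place on the phenyl ring. They also leave open whether trifluoromethyl would give a readable value on the core of compound 2, which has no bromo.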